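This account rests on a few compounds, and the source may have more. Where it says the series, first, only, none or still open, it means among the compounds named here.

Measured so far:
- compound 1, `CCNC(=O)C1=C(C)NC(=O)NC1c1cccs1`, gives 1% in an assay on membranes from CHO cells for displacement of a labelled ligand from adenosine receptor A1 (Homo sapiens), read by scintillation counting, with a stated time of 60 min, tested at 1 uM; a lower number here means less inhibition, a higher number more inhibition at the concentration tested (going by the name of the read-out)
- compound 2, `CCN(CC)C(=O)C1=C(C)NC(=O)NC1c1cccs1`, gives 13%
- compound 3, `CC1=C(C(N)=O)C(c2ccsc2)NC(=O)N1`, gives 2%

Compound 4, `CCNC(=O)C1=C(C)NC(=O)NC1c1ccsc1`, has not been measured yet. It differs from compound 3 by one change: ethyl in place of hydrogen on an amide-type nitrogen. The same kind of change separates compound 1 from compound 2: ethyl in place of hydrogen on an amide-type nitrogen. The two are not identical, though: in compound 1 the amide-type nitrogen carries a carbonyl carbon and a saturated chain carbon as its other neighbours, whereas in compound 3 it carries only a carbonyl carbon. How the cores of compound 1 and compound 3 differ is not broken down here.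

Among the compounds with values here, the one measured step of this kind, a number 12 percentage points higher from compound 1 to compound 2 (beyond the scatter), is modest but beyond the scatter. Compound 1, which already carries the ethyl group on an amide-type nitrogen, and compound 3 give numbers within the scatter of each other. The step from compound 3 to compound 4 is therefore expected to be small, a number 3 percentage points higher from compound 3 to compound 4 (within the scatter), because compound 1 in this assay gives 1%. Compound 4 is estimated to give 5%, with a range from 0% to 16%.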

Compound 4, a percentage reported as inhibition, at one concentration (the size of the read-out at that concentration, not a potency): 3%
Compound 4: middle estimate off by 2 percentage points, on the high side; the range from low to high includes it.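

In this assay, ethyl in place of hydrogen on an amide-type nitrogen gives a number 1 percentage points higher from compound 3 to compound 4 (within the scatter), and the two cores do not separate when this is set beside the earlier step: the same change on two cores in this assay, a number 12 percentage points higher (beyond the scatter) from compound 1 to compound 2 and a number 1 percentage points higher (within the scatter) from compound 3 to compound 4, 11 percentage points apart, within the scatter of two such steps. This shows no measurable dependence of the change on the core, but it does not prove that the change carries over unaltered: the earlier step puts a second ethyl on a nitrogen that already has one, whereas the new step puts the first ethyl on a nitrogen that has none. The cores themselves differ by thiophen-3-yl in place of thiophen-2-yl on a saturated ring carbon, which gives a number 2 percentage points higher from compound 1 to compound 4 (within the scatter), and these percentages at one concentration are not potencies.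

The compounds shown leave open what a longer chain, such as propyl or butyl, would do on the amide-type nitrogen. They also leave open whether a phenyl ring in place of the thiophene, or a carboxylic acid in place of the amide, would change the read-out.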